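A few compounds are considered here, and "the series" means these few. Any claim that something is new, unique, unknown or untested is made for them only; others in the source may bear on it.

In a functional assay on the whole organism with Scenedesmus acutus as the target, with a stated time of 20 h (a lower number here means a stronger inhibitor, a higher number a weaker inhibitor), compound 3 `S=c1n(-c2ccc(Cl)cc2)c(=S)n2n1CCCC2` gives 50.1 nM. Compound 2 `CC(C)Oc1cc(-n2c(=S)n3n(c2=S)CCCC3)c(F)cc1Cl` gives 67.6 nM, within the scatter of compound 3. Compound 1 `Cc1cc(Cl)ccc1/N=c1\sc(=S)n2n1CCCC2` gives 513 nM, a higher number than compound 3 and beyond the scatter. Compound 4 `S=c1n(-c2ccccc2)c(=S)n2n1CCCC2` is the next point: hydrogen in place of chloro on an aromatic carbon, with hydrogen in place of chloro on an aromatic carbon. Within the data shown here, no measured pair isolates this change, and all three measured compounds carry a chloro on their aromatic ring, so the expectation is a judgement: a weaker inhibitor, with a rise in the number beyond the scatter. The expected size is a 5.0-fold higher number from compound 3 to compound 4 (0.70 log units; beyond the scatter). For compound 4 the estimated value is 250 nM, with an expected range of 80 nM to 800 nM.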

Compound 4, half-maximal inhibitory concentration: 2040 nM
For compound 4 the middle estimate is 8.2-fold (0.91 log units) below the measured one; the measured number lies above the stated range.
By their numbers in this assay, from the lowest: compounds 3 and 2 (each within the scatter of the next); then compound 1; then compound 4.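

Among these compounds, replacing the chloro para to a large group with hydrogen gives a 41-fold higher number from compound 3 to compound 4 (1.61 log units; beyond the scatter), the first reading of a single change. This position on the aromatic ring is therefore not indifferent to its substituent, at least on the shared core of compound 3 and compound 4. No measured evidence bears on the origin of this step.

Going by these compounds, whether bromo, methoxy or an amine at this position would keep the number of compound 3 stays open. So does whether the same step holds on the core of compound 1 or alongside the other ring groups of compound 2.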